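The source may report more compounds than this note shows. Statements on the series, on what has been measured and on what is new or still open speak of the compounds shown alone.

All four compounds share one core, a bromo-substituted bicyclic amine bearing a benzyl group, and differ only in what sits on the benzyl ring. Compound 1 `ONc1ccc(CNc2cc(Br)cc3[nH]ncc23)cc1` carries a hydroxylamine there; in an assay for inhibition of Tryptophan 2,3-dioxygenase (Homo sapiens), with a stated time of 1 h, tested at 10 uM (on this read-out higher numbers stand for more inhibition at the one concentration tested (going by the name of the read-out) and lower numbers for less inhibition), compound 1 gives 6%. Compound 3 `Oc1ccc(CNc2cc(Br)cc3[nH]ncc23)cc1Cl` carries a hydroxy group and a chloro; in this assay compound 3 gives 19%. Compound 2 `Oc1ccc(CNc2cc(Br)cc3[nH]ncc23)c(O)c1` carries two hydroxy groups, and in this assay compound 2 was reported as "not active" (no number reported), so no single number describes where it stands, and the verdict reported for compound 2 is all there is; only compound 1 and compound 3 carry numbers in this assay.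

The step to compound 4 `Oc1ccc(CNc2cc(Br)cc3[nH]ncc23)c(F)c1` is a single change: fluoro in place of hydroxy on an aromatic carbon. Going by the values given here, no measured pair in this set isolates that change, so its effect is not known here. Given that compound 1 gives 6% and compound 3 gives 19%, a number in the same neighbourhood as these two, with no clear direction, is expected in this assay. Compound 4 is therefore estimated to give about 8%, with a range from 0% to 20%.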

Compound 4, a percentage reported as inhibition, at one concentration (the size of the read-out at that concentration, not a potency): "not active" (no number reported)
The entry for compound 4 holds no number, so the estimate cannot be set against anything.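

Compound 2 and compound 4 were both reported in this assay as not active, without a number, so no step can be read between them. The compounds shown leave open whether fluoro in place of hydroxy at this spot changes inhibition at all, and by how much. Nothing measured here offers an explanation for this result.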